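The source may hold more compounds than are shown below. What is called first, only, known or untested is meant among the compounds shown, and "the series" means these compounds.

Measured so far:
compound 1 `Fc1ccc(-c2cn(C3CN4CCC3CC4)nn2)cc1`: 449 nM
compound 2 `c1ccc(COc2cccc(-c3cn(C4CN5CCC4CC5)nn3)c2)cc1`: 668 nM

In an assay on HEK293 cells for displacement of a labelled ligand from Neuronal acetylcholine receptor; alpha4/beta2 (Homo sapiens), read by scintillation counting, with a stated time of 120 min (on this read-out higher numbers stand for weaker inhibition and lower numbers for stronger inhibition), compound 1 gives 449 nM and compound 2 gives 668 nM; the two numbers sit within the scatter of each other, so neither stands apart. Among the compounds with values here, no single-change step between measured compounds is available as a guide.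

Compound 3 `Oc1ccc(-c2cn(C3CN4CCC3CC4)nn2)cc1` is next: hydroxy in place of fluoro on an aromatic carbon. Nothing measured in this series shows what such an exchange does, so no direction is supported; the expected step from compound 1 to compound 3 is a 1.0-fold higher number from compound 1 to compound 3 (0.00 log units; within the scatter), within the scatter. For compound 3 the estimate in this assay is 450 nM, with a range of 150 nM to 1400 nM.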

Compound 3, inhibition constant: 627 nM
Estimate against measurement, compound 3: 1.4-fold (0.14 log units) below, within the range that was stated.
By their numbers in this assay, from the lowest: compounds 1, 3 and 2 (each within the scatter of the next).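

In this assay, hydroxy in place of fluoro on an aromatic carbon, para to a large group, gives a 1.4-fold higher number from compound 1 to compound 3 (0.15 log units; within the scatter). Within the data shown here, this is the first single-change reading at this position: the exchange adds a hydrogen-bond donor and a hydrogen-bond acceptor, yet the two numbers cannot be told apart. No measurement at hand gives a reason for this result. Still open, as far as these compounds go, is whether an amine, a carboxylic acid or a methoxy group at this place would read differently from fluoro and hydroxy. Also open, from the compounds shown here alone, is whether the same exchange reads alike on another aromatic carbon.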